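The source may report more compounds than this note shows. Statements on the series, on what has been measured and on what is new or still open speak of the compounds shown alone.

The measured compounds are:
compound 1 `CCCCC(O)Cn1cc(CN(C)CC2CCCCC2)nn1` with 47%
compound 2 `OC(COCc1ccccc1)Cn1cc(CN2CCN(c3ccccc3)CC2)nn1` with 37%
compound 3 `CCCCNC(=O)OCC(O)Cn1cc(CN2CCN(c3ccccc3)CC2)nn1` with 11%

In an assay on nucleic acid for inhibition of Nucleic Acid, read by fluorescence, tested at 100 uM (a higher number here means more inhibition at the concentration tested (going by the name of the read-out), a lower number less inhibition), compound 1 gives 47%, compound 2 gives 37% and compound 3 gives 11%. Compound 3 stands lowest of the three numbers; compound 2 is nearest to it and compound 1 furthest, and both gaps lie beyond the scatter. Compound 2 and compound 3 share the same core and differ in one place, a step of a number 26 percentage points lower from compound 2 to compound 3 (beyond the scatter) when butylcarbamoyl replaces benzyl on an oxygen on a saturated carbon.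

Compound 4 `O=C(NCc1ccccc1)OCC(O)Cn1cc(CN2CCN(c3ccccc3)CC2)nn1` has not yet been measured in this assay. It differs from compound 3 in one place: phenyl in place of propyl on a saturated chain carbon bound to an amide-type nitrogen. Cut one bond further out, this reads butylcarbamoyl to benzylcarbamoyl. Among the compounds with values here, the only measured step that bears on it is the one from compound 2 to compound 3, where losing the benzyl group and gaining butylcarbamoyl lowered inhibition by a modest amount. Compound 4 keeps the carbamoyl part of compound 3 but brings a phenyl ring back, so that step is a loose guide at best. A modest rise in this assay is therefore expected, a number 14 percentage points higher from compound 3 to compound 4 (beyond the scatter), though a change within the scatter remains possible. Compound 4 is estimated at 25%, with a range from 8% to 45%.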

Compound 4, a percentage reported as inhibition, at one concentration (the size of the read-out at that concentration, not a potency): 32%
The estimate for compound 4 lay 7 percentage points below the measured number; the range from low to high includes it.
By their numbers in this assay, from the lowest: compound 3; then compounds 4, 2 and 1 (each within the scatter of the next, the first and the last beyond it).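

In this assay the change at this position, phenyl in place of propyl on a saturated chain carbon bound to an amide-type nitrogen, gives a number 21 percentage points higher from compound 3 to compound 4 (beyond the scatter) and so shows that the group at the far end of the carbamoyl unit affects the read-out. The earlier step (a number 26 percentage points lower from compound 2 to compound 3 (beyond the scatter)) changed the whole group on the oxygen at once, so it could not separate the carbamoyl unit from the loss of the phenyl ring; the new step (a number 5 percentage points lower from compound 2 to compound 4 (within the scatter)) now shows that with the benzyl kept, adding the carbamoyl unit leaves the number within the scatter, which ties the low value of compound 3 to its butyl chain rather than to the carbamoyl unit, at least among these three compounds. No measurement shown here explains why phenyl and propyl differ at this position.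

From the compounds shown here alone, whether the ring has to be aromatic remains open, and cyclohexylmethyl in place of benzyl would bear on that. Also open, going by these compounds, is how the length of the link to the ring matters, as a phenethyl group would show, and compound 1 differs in too many places to help with either question.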